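Sigma-2 series: anilide side chain swap from compound 1

This account rests on a few compounds, and the source may have more. Where it says the series, first, only, none or still open, it means among the compounds named here.

Measured compounds in this set:
- compound 1, `Cc1c(Cl)cccc1NC(=O)CN1CCC(OCc2ccc(F)c(F)c2)CC1`: 299 nM
- compound 2, `Fc1ccc(CN2CCCC23CCN(Cc2cn4ccccc4n2)C3)cc1F`: 23 nM
- compound 3, `Cc1ccc(CN2CCC[C@H](OCc3ccc(F)c(C)c3)C2)cc1`: 76 nM

All three values come from an assay on membranes from HEK293 cells for displacement of a labelled ligand from Sigma intracellular receptor 2 (Homo sapiens); a lower number here means a stronger inhibitor, a higher number a weaker inhibitor. Compound 1 has the highest number of the three, and both gaps fall beyond the usual scatter: compound 3 gives 76 nM and compound 2 gives 23 nM, so compound 1 is the weakest inhibitor among the measured compounds. Compound 2 and compound 3 share no single-point relation with compound 1; their numbers only set the range seen so far.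

Compound 4, `Cc1cc(NC(=O)CN2CCC(OCc3ccc(F)c(F)c3)CC2)ccc1F`, is the next compound to be measured in this assay. It differs from compound 1 in one place: 4-fluoro-3-methylphenyl in place of 3-chloro-2-methylphenyl on an amide-type nitrogen. Cut one bond further out, the change reads (3-chloro-2-methylphenyl)amino to (4-fluoro-3-methylphenyl)amino. Going by the values given here, no measured pair in this set isolates such a change, so its size is not known from these data.

The expectation for this assay is a small step from compound 1 to compound 4, if any, of a 1.3-fold higher number from compound 1 to compound 4 (0.13 log units; within the scatter), probably not beyond the scatter. Compound 4 is therefore estimated at 400 nM, with a range from 130 nM to 1200 nM.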

Compound 4, inhibition constant: 123 nM
The estimate for compound 4 lay 3.3-fold (0.51 log units) above the measured number; the measured number lies below the stated range.
By their numbers in this assay, from the lowest: compound 2; then compounds 3 and 4 (each within the scatter of the next); then compound 1.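

In this assay the aryl group on the amide-type nitrogen is now shown to influence the number: 4-fluoro-3-methylphenyl in place of 3-chloro-2-methylphenyl gives a 2.4-fold lower number from compound 1 to compound 4 (0.39 log units; beyond the scatter), a modest step but beyond the scatter, and the only one in the set that isolates a single place. The two groups match in everything counted for them, with the same number of heavy atoms, one six-membered aromatic ring of carbon only, no hydrogen-bond donors or acceptors and no net charge, so these counts do not separate them even though the number moves. No measurement at hand bears on why the number moves.

Chlorine gives way to fluorine and the substituents change their places on the ring in the same step, so the contribution of each remains open. Also open, as far as these compounds go, is how the number would respond at this position to an aryl ring carrying an amine or a carboxylic acid, or to a longer chain in place of the methyl group.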